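Glycine transporter 1 series: amide nitrogen substituent, next step

A few compounds are considered here, and "the series" means these few. Any claim that something is new, unique, unknown or untested is made for them only; others in the source may bear on it.

Measured so far in an assay on HEK293 cells for inhibition of sodium- and chloride-dependent glycine transporter 1 (Homo sapiens), read by scintillation proximity assay; a higher number here means a weaker inhibitor, a lower number a stronger inhibitor:
- compound 1 `O=C(CN(C(=O)c1ccc(-c2ccccn2)cc1)C1CCCOC1)Nc1cc(F)cc(F)c1`: 79.4 nM
- compound 2 `O=C(CN(C(=O)c1ccc(-c2ccccn2)cc1)C1CCOCC1)Nc1cc(F)cc(F)c1`: 1000 nM
- compound 3 `O=C(CN(CC1CCC1)C(=O)c1ccc(-c2ccccn2)cc1)Nc1cc(F)cc(F)c1`: 126 nM

Compound 3 stands second highest of the three numbers. Its nearest neighbour is compound 1, with a 1.6-fold higher number from compound 1 to compound 3 (0.20 log units; within the scatter); its furthest is compound 2, with a 7.9-fold lower number from compound 2 to compound 3 (0.90 log units; beyond the scatter). Compound 4 `CCC(COC)N(CC(=O)Nc1cc(F)cc(F)c1)C(=O)c1ccc(-c2ccccn2)cc1` differs from compound 3 by 1-(methoxymethyl)propyl in place of cyclobutylmethyl on an amide-type nitrogen.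

Within the data shown here, the steps that bear on this change are those at the same amide-type nitrogen. The ring-oxygen shift gave a 13-fold higher number from compound 1 to compound 2 (1.10 log units; beyond the scatter), while exchange of the ring for the cyclobutylmethyl group gave a 7.9-fold lower number from compound 2 to compound 3 (0.90 log units; beyond the scatter) and a 1.6-fold higher number from compound 1 to compound 3 (0.20 log units; within the scatter). Among the measured compounds shown here, no measured compound carries an acyclic ether at this nitrogen, so the new group has no direct precedent here; the data show only that an oxygen-bearing substituent can sit anywhere across a wide range. A modest step is therefore expected, in either direction, with a wide margin.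

For compound 4 the step is expected to be a 1.3-fold higher number from compound 3 to compound 4 (0.10 log units; within the scatter). Compound 4 is estimated at 160 nM in this assay, within 40 nM to 630 nM.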

Compound 4, half-maximal inhibitory concentration: 1260 nM
Compound 4: middle estimate off by 7.9-fold (0.90 log units), on the low side, outside the stated range (above it).
By their numbers in this assay, from the lowest: compounds 1 and 3 (each within the scatter of the next); then compounds 2 and 4 (each within the scatter of the next).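

In this assay, 1-(methoxymethyl)propyl on the amide-type nitrogen does not match cyclobutylmethyl or oxan-3-yl: the changes give a 10-fold higher number from compound 3 to compound 4 (1.00 log units; beyond the scatter) and a 16-fold higher number from compound 1 to compound 4 (1.20 log units; beyond the scatter) at this position. Against oxan-4-yl the same group gives a 1.3-fold higher number from compound 2 to compound 4 (0.10 log units; within the scatter) and so joins compound 2 at the high end, while compounds 1 and 3 stay together at the low end. An ether oxygen in the substituent therefore does not set the number on its own, since compound 1 carries one and still sits with the oxygen-free compound 3, and nothing measured here explains this split.

Open, from the compounds shown here alone, is whether the branch in 1-(methoxymethyl)propyl or the open chain itself goes with the higher number, which an unbranched 2-methoxyethyl group would test. Also open, going by these compounds, is how a basic amine such as piperidin-3-yl behaves at this nitrogen in place of oxan-3-yl.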